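Nitrile for chloro on the benzamide ring: cytotoxicity notes

This account rests on a few compounds, and the source may have more. Where it says the series, first, only, none or still open, it means among the compounds named here.

Compound 1 `CCS(=O)(=O)Nc1ccc(NC(=O)c2ccc(Cl)cc2)cc1C`, compound 2 `CCS(=O)(=O)Nc1ccc(NC(=O)c2ccc(C#N)cc2)cc1C` and compound 3 `O=C(Nc1ccc(NS(=O)(=O)C(F)(F)F)c(Cl)c1)c1ccc(Cl)cc1` are the measured members of the series. In an ADME assay on HEK293 cells (Homo sapiens) for cytotoxicity, read by MTT assay, with a stated time of 48 h (a higher number here means a weaker inhibitor, a lower number a stronger inhibitor), compound 1 gives 125000 nM. In this assay compound 3 gives 191000 nM, a value that lies within the scatter of compound 1. For compound 2 the this assay result is a limit of the assay, > 250000 nM, in line with the limit of > 250000 nM in this assay, at which 1 of the 3 values shown sits. Among the measured compounds shown here, the single counted change there, (cyano in place of chloro on an aromatic carbon), gave an at least 2.0-fold higher number from compound 1 to compound 2 (0.30 log units; that floor lies within the scatter). How the core of compound 3 differs from the core of compound 1 is not broken down here. Compound 4 `N#Cc1ccc(C(=O)Nc2ccc(NS(=O)(=O)C(F)(F)F)c(Cl)c2)cc1` carries the same change on the core of compound 3: cyano in place of chloro on an aromatic carbon. Beside an at least 2.0-fold higher number from compound 1 to compound 2 (0.30 log units; that floor lies within the scatter), the step of a 1.7-fold higher number from compound 3 to compound 4 (0.22 log units; within the scatter) is expected, resting on that earlier step alone. In this assay compound 4 is therefore expected to give 320000 nM, between 160000 nM and 640000 nM, with a fair chance that only a limit is returned.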

Compound 4, half-maximal inhibitory concentration: > 250000 nM
Compound 4 ended at the assay's limit; the forecaster's own chance of this, stated with the estimate: 60%; the middle value lies beyond the limit too.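

In this assay, cyano in place of chloro on the core of compound 3 gave an at least 1.3-fold higher number from compound 3 to compound 4 (0.11 log units; that floor lies within the scatter). Compound 4, like compound 2, returned only a limit of the assay: the limit of > 250000 nM in this assay, at which 2 of the 4 values shown sit. The change therefore reaches that limit on both cores, but each step is only a floor, and neither shows a size beyond the scatter or that the size carries over from one core to the other: the same change on two cores in this assay, an at least 2.0-fold higher number (0.30 log units; that floor lies within the scatter) from compound 1 to compound 2 and an at least 1.3-fold higher number (0.11 log units; that floor lies within the scatter) from compound 3 to compound 4; the limit leaves it open whether they differ.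

As far as these compounds go, the actual values of compound 2 and compound 4 remain open. Also open, from the compounds shown here alone, is whether a different group on the same aromatic carbon, such as an amine or a carboxylic acid, would give a number that can be read on both cores.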